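The source may report more compounds than this note shows. Statements on the series, on what has been measured and on what is new or still open speak of the compounds shown alone.

Measured so far in a functional assay on PC-3 cells (Homo sapiens) for inhibition, read by sulforhodamine B assay, with a stated time of 48 h; on this read-out lower numbers stand for stronger inhibition and higher numbers for weaker inhibition:

- compound 1, `COC(=O)[C@@]1(C)C[C@@H](c2coc3ccc(Br)cc3c2=O)N(c2ccccc2)O1`: > 60000 nM
- compound 2, `O=C1[C@H]2[C@H](ON(c3ccccc3)[C@@H]2c2coc3ccc(F)cc3c2=O)C(=O)N1c1ccccc1`: > 60000 nM
- compound 3, `O=C1[C@H]2[C@H](ON(c3ccccc3)[C@@H]2c2coc3ccc(Br)cc3c2=O)C(=O)N1c1ccccc1`: 13300 nM

Compound 1 stands at a limit of this assay, not at a number, so for compound 1 only a bound is known. Compound 2 likewise sits at a limit of this assay and gives no number. Going by the values given here, compound 3 is the one member of the set with a measured number in this assay, 13300 nM.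

The change from compound 3 to compound 2 is fluoro in place of bromo on an aromatic carbon. It produced an at least 4.5-fold higher number from compound 3 to compound 2 (0.65 log units; beyond the scatter), so the bromo compound is the one that registers and the fluoro compound does not. The difference between the core of compound 1 and the core of compound 3 is not broken down here.

Compound 4, `COC(=O)[C@@]1(C)C[C@@H](c2coc3ccc(F)cc3c2=O)N(c2ccccc2)O1`, is not yet measured. Among the compounds with values here, it differs from compound 1 by fluoro in place of bromo on an aromatic carbon, the same change as the one made from compound 3 to compound 2, at the same place. Compound 1 is already at the limit of > 60000 nM in this assay, at which 2 of the 3 values shown sit, so a step in the same direction cannot be resolved as a number in this assay. For compound 4 a value at or beyond the same limit is expected, that is, a step that the limit leaves unreadable from compound 1 to compound 4, resting on the direction seen from compound 3 to compound 2 and on the limit of compound 1. The expected value for compound 4 in this assay is 120000 nM, with a range from 60000 nM to 300000 nM.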

Compound 4, half-maximal inhibitory concentration: 31300 nM
Compound 4: the middle estimate sits 3.8-fold (0.58 log units) above what was measured, and the stated range ends above it.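

In this assay, fluoro in place of bromo on an aromatic carbon gives an at least 1.9-fold lower number from compound 1 to compound 4 (0.28 log units; that floor lies within the scatter), the reverse of the direction seen on the other core. The same change therefore does not carry over unchanged between these two cores, and the two steps differ by more than the scatter: the same change on two cores in this assay, an at least 4.5-fold higher number (0.65 log units; beyond the scatter) from compound 3 to compound 2 and an at least 1.9-fold lower number (0.28 log units; that floor lies within the scatter) from compound 1 to compound 4, at least 8.6-fold (0.93 log units) apart, beyond the scatter of two such steps

What this does not show is the true size of either step or any reason for the reversal, since compound 1 and compound 2 give limits, not numbers, and each step is only a floor: the limit of > 60000 nM in this assay, at which 2 of the 4 values shown sit.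

The compounds shown cover only bromo and fluoro at this place, on two cores, so it remains open whether chloro, methoxy or an amine there would follow the bromo or the fluoro compounds on each core. Also open, as far as these compounds go, is whether a carboxylic acid in place of the methyl ester of compound 4 would leave the reading in this assay unchanged, and whether a third core would side with compound 1 and compound 4 or with compound 2 and compound 3.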